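A few compounds are considered here, and "the series" means these few. Any claim that something is new, unique, unknown or untested is made for them only; others in the source may bear on it.

Compound 1, `C[Se]c1nc(N)c2ccccc2n1`, was tested in a functional assay on HTB-54 cells (Homo sapiens) for cytotoxicity, read by MTT assay, with a stated time of 72 h (a higher number here means a weaker inhibitor of growth, a lower number a stronger inhibitor of growth), where compound 1 gives 18000 nM. Among the three compounds measured so far, that number is the second highest. The nearest neighbour is compound 3, `CCCCC[Se]c1nc(N)c2cccnc2n1`, which gives 8780 nM, a lower number than that of compound 1, and the gap between the two is beyond the usual scatter. The furthest is compound 2, `CCCCC[Se]c1nc(NCc2ccc(SC)cc2)c2ccccc2n1`, which gives 40400 nM, a higher number than that of compound 1, again by a gap beyond the scatter. None of these three compounds is linked to another by a change in only one place, so their values can only be set side by side.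

Compound 4, `Nc1nc([SeH])nc2ccccc12`, has not yet been measured in this assay. It differs from compound 1 by hydrogen in place of methyl on a selenium. For the measured compounds named here, no measured pair shows what taking the methyl off the selenium does, so no step can be borrowed from the data. Without such a guide, the change is expected to stay within the usual scatter, with no clear direction. The expected step is no change at the digits printed from compound 1 to compound 4 (within the scatter). Compound 4 is therefore estimated to give about 18000 nM in this assay, with a range from 7000 nM to 45000 nM.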

Compound 4, concentration for 50% growth inhibition: 40 nM
The estimate for compound 4 lay 450-fold (2.65 log units) above the measured number; measured number outside the range, below it.
By their numbers in this assay, from the lowest: compound 4; then compound 3; then compound 1; then compound 2.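

In this assay, the group on the selenium turns out to matter a great deal: hydrogen in place of methyl gives a 450-fold lower number from compound 1 to compound 4 (2.65 log units; beyond the scatter), a large step beyond the scatter. The earlier compounds shown here could not show this, since none of them was linked to another by a change in only one place, whereas this pair isolates the selenium substituent and shows that removing a methyl, a single carbon with no ring and no net charge, is enough to shift growth inhibition this far. For the compounds shown here, nothing measured so far explains why so small a change has so large an effect.

A single pair cannot show whether any group on the selenium weakens growth inhibition as methyl does, or whether an ethyl group or a longer chain would behave differently from methyl. It also leaves open whether the selenium itself is needed, which a thiol in place of the selenium-bound hydrogen of compound 4 would test, and whether the same step would appear on other cell lines.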